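Swapping a Triazole for a Methoxy Group on the Side Chain

The compounds below may be only part of what the source reports. "The series", "measured", "known", "first", "only" and "open" are said of these compounds alone.

Three compounds built on one shared core were tested in a functional assay on HCT-116 cells (Homo sapiens) for antiproliferative activity, read by sulforhodamine B assay, with a stated time of 72 h; on this read-out lower numbers stand for stronger inhibition and higher numbers for weaker inhibition. Compound 1 `Cn1ncc(Cl)c1-c1cc(C(=O)N[C@@H]2CNCC[C@H]2c2ccc(C(F)(F)F)cc2)oc1Cl` gives 280 nM. Compound 2 `Cn1ncc(Cl)c1-c1cc(C(=O)N[C@@H]2CN[C@H](CCn3cncn3)C[C@H]2c2ccc(Cl)c(Cl)c2)oc1Cl` gives 560 nM, the second highest of the three numbers, and compound 3 `CC(=O)NCC[C@@H]1C[C@@H](c2ccc(F)c(F)c2)[C@H](NC(=O)c2cc(-c3c(Cl)cnn3C)c(Cl)o2)CN1` gives 920 nM. The gaps from compound 2 to either neighbour fall within the scatter, so no order among the three can be read.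

Compound 4 `COCC[C@@H]1C[C@@H](c2ccc(Cl)c(Cl)c2)[C@H](NC(=O)c2cc(-c3c(Cl)cnn3C)c(Cl)o2)CN1` is the unmeasured partner of compound 2. The change is methoxy in place of 1H-1,2,4-triazol-1-yl on a saturated chain carbon, two bonds along the chain from a saturated ring carbon. Within the data shown here, no measured pair shows what this change does. Because the values of compounds 1, 2 and 3 sit so close together, the step expected here, a 1.2-fold lower number from compound 2 to compound 4 (0.09 log units; within the scatter), is small and likely none beyond the scatter. Compound 4 is therefore estimated at 450 nM, within 150 nM to 1500 nM.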

Compound 4, half-maximal inhibitory concentration: 470 nM
The estimate for compound 4 lay 1.0-fold (0.02 log units) below the measured number; measured number inside the range.
By their numbers in this assay, from the lowest: compounds 1, 4, 2 and 3 (each within the scatter of the next, the first and the last beyond it).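

Among these compounds, this is the first measured pair at this position on the side chain, and this assay gives a 1.2-fold lower number from compound 2 to compound 4 (0.08 log units; within the scatter). The 1H-1,2,4-triazol-1-yl group, with its five-membered aromatic ring, can therefore be replaced by the smaller, ring-free methoxy without a change beyond the scatter. No available evidence bears on this result.

Going by these compounds, how an amine, a carboxylic acid or a longer chain would fare at this position remains open. A single pair also cannot show whether this swap would read the same on another compound.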